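Shifting One Methyl Group on a Sulfonamide Nitrogen Substituent

The source may hold more compounds than are shown below. What is called first, only, known or untested is meant among the compounds shown, and "the series" means these compounds.

Four compounds share one core and differ only in the groups on a sulfonamide nitrogen. Three of them have been tested in a functional assay on DU-145 cells (Homo sapiens) for antiproliferative activity, read by MTT assay, with a stated time of 72 h; on this read-out lower numbers stand for stronger inhibition and higher numbers for weaker inhibition. Compound 1 (`Cc1cccc(N(C)S(=O)(=O)C2CC3OC2C(c2ccc(NC(=O)CCCCCCC(=O)O)cc2)=C3c2ccc(O)cc2)c1`) reads > 100000 nM, and this is a limit of the assay, not a number. Compound 2 (`CN(c1cccc2ccccc12)S(=O)(=O)C1CC2OC1C(c1ccc(NC(=O)CCCCCCC(=O)O)cc1)=C2c1ccc(O)cc1`) gives 70900 nM. Compound 3 (`CCN(c1ccc(C)cc1)S(=O)(=O)C1CC2OC1C(c1ccc(NC(=O)CCCCCCC(=O)O)cc1)=C2c1ccc(O)cc1`) gives 53500 nM, which puts it level with compound 2 within the scatter, as a 1.3-fold lower number from compound 2 to compound 3 (0.12 log units; within the scatter) shows.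

Compound 4 (`CCN(c1cccc(C)c1)S(=O)(=O)C1CC2OC1C(c1ccc(NC(=O)CCCCCCC(=O)O)cc1)=C2c1ccc(O)cc1`) has not been measured yet and differs from compound 3 in one place: 3-methylphenyl in place of 4-methylphenyl on a sulfonamide nitrogen. In words, this is 3-methylphenyl in place of 4-methylphenyl on a sulfonamide nitrogen.

For the measured compounds named here, no measured step makes this change alone. The closest is an at least 1.8-fold lower number from compound 1 to compound 3 (0.27 log units; that floor lies within the scatter), which contains the same exchange between the two methylphenyl groups along with a second change on the nitrogen. The other step from compound 1 is an at least 1.4-fold lower number from compound 1 to compound 2 (0.14 log units; that floor lies within the scatter). Neither shows a change beyond the scatter, so no clear shift in either direction is expected in this assay. The expected size is a 1.1-fold higher number from compound 3 to compound 4 (0.05 log units; within the scatter). For compound 4 the estimated value is 60000 nM, with an expected range from 30000 nM to 110000 nM.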

Compound 4, half-maximal inhibitory concentration: 65600 nM
Estimate against measurement, compound 4: 1.1-fold (0.04 log units) below; measured number inside the range.
By their numbers in this assay, from the lowest: compounds 3, 4 and 2 (each within the scatter of the next). At a limit, above all of these: compound 1.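

Moving the methyl group is now seen on its own: with 3-methylphenyl in place of 4-methylphenyl on the sulfonamide nitrogen, this assay gives a 1.2-fold higher number from compound 3 to compound 4 (0.09 log units; within the scatter), so the two compounds cannot be told apart here. Replacing methyl(naphthalen-1-yl)amino with ethyl(3-methylphenyl)amino, a larger exchange at the same place, gives a 1.1-fold lower number from compound 2 to compound 4 (0.03 log units; within the scatter), so these two compounds cannot be separated either. The third step is the first to isolate methyl in place of hydrogen on the saturated chain carbon bound to the sulfonamide nitrogen, and it gives an at least 1.5-fold lower number from compound 1 to compound 4 (0.18 log units; that floor lies within the scatter), but it starts from the reading of compound 1, which is a limit of the assay and not a number, so its true size stays unknown: the limit of > 100000 nM in this assay, at which 1 of the 4 values shown sits.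

The compounds shown leave open whether a propyl chain in place of ethyl on the sulfonamide nitrogen would read any differently from these values. They also leave open whether a methoxyphenyl or chlorophenyl group in place of the methylphenyl group, with atoms other than carbon in the substituent on the ring, would move the number beyond the scatter.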